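Swapping the aryl group on a cytotoxicity read-out

A few compounds are considered here, and "the series" means these few. Any claim that something is new, unique, unknown or untested is made for them only; others in the source may bear on it.

For the measured compounds named here, compound 2 `Cc1ccc(N(C(=O)c2c(F)cccc2F)C(=S)OCCN2C(=O)c3ccccc3C2=O)cc1` is one of two compounds measured in an ADME assay on MT4 cells (Homo sapiens) for cytotoxicity, read by MTT assay; on this read-out lower numbers stand for higher toxicity in this test and higher numbers for lower toxicity in this test. In this assay compound 2 gives 65000 nM, the higher of the two numbers, while compound 1 `O=C1c2ccccc2C(=O)N1CCOC(=S)N(C(=O)c1ccc(Cl)c([N+](=O)[O-])c1)c1ccc(Cl)cc1` gives 48000 nM; the two lie within the usual scatter of each other. Compound 3 `Cc1ccc(N(C(=O)c2ccc(Cl)c([N+](=O)[O-])c2)C(=S)OCCN2C(=O)c3ccccc3C2=O)cc1` is not yet measured. It differs from compound 2 in one place: 4-chloro-3-nitrophenyl in place of 2,6-difluorophenyl on a carbonyl carbon. Compound 1 already carries this group and gives 48000 nM, close to compound 2. The step is therefore expected to stay within the scatter, a 1.3-fold lower number from compound 2 to compound 3 (0.11 log units; within the scatter). Compound 3 is estimated at 50000 nM, with a range from 25000 nM to 100000 nM.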

Compound 3, half-maximal cytotoxic concentration: 47000 nM
Compound 3: the middle estimate sits 1.1-fold (0.03 log units) above what was measured, within the range that was stated.
By their numbers in this assay, from the lowest: compounds 3, 1 and 2 (each within the scatter of the next).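

In this assay putting 4-chloro-3-nitrophenyl in place of 2,6-difluorophenyl on the carbonyl carbon gives a 1.4-fold lower number from compound 2 to compound 3 (0.14 log units; within the scatter) and so does not separate these two aryl groups. With 4-chloro-3-nitrophenyl held fixed, methyl in place of chloro on an aromatic carbon gives a 1.0-fold lower number from compound 1 to compound 3 (0.01 log units; within the scatter) and likewise separates nothing. Nothing shown here explains either result. Still open, going by these compounds, is whether a group of another kind on this carbonyl carbon, such as a cyclohexyl ring or a phenyl ring carrying an amine or a carboxylic acid, would give a number beyond the scatter.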